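Amine swap on the benzamide of compound 3

The source may report more compounds than this note shows. Statements on the series, on what has been measured and on what is new or still open speak of the compounds shown alone.

Working notes on the series. The three measured compounds share a core bearing a fluorinated methoxyphenyl group and an amide-linked benzamide, and differ in the amine carried on the benzamide ring. Compound 1 `COc1cccc(-c2ccc3c(NC(=O)c4ccc(N5CCN(C)CC5)c(F)c4)n[nH]c3c2)c1F` in a functional assay on SNU-16 cells (Homo sapiens) for antiproliferative activity, read by CCK-8 assay, with a stated time of 72 h (a higher number here means a weaker inhibitor, a lower number a stronger inhibitor), gives > 1000 nM, which is a limit of the assay and not a number. Compound 2 `CCN1CCN(c2ccc(C(=O)Nc3n[nH]c4cc(-c5cccc(OC)c5F)ccc34)cc2C(F)(F)F)CC1` in this assay gives > 1000 nM, again only a limit. Among the measured compounds shown here, compound 3 `COc1ccc(F)c(-c2ccc3c(NC(=O)c4ccc(N5CCCN(C)CC5)cc4)n[nH]c3c2)c1F` in this assay gives 102 nM, the only measured number among the three; the rest of the set is characterised by the limit of > 1000 nM in this assay, at which 2 of the 3 values shown sit. Compound 3 is thus the single numerical reference point.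

Compound 4 `COc1ccc(F)c(-c2ccc3c(NC(=O)c4ccc(N5C[C@@H](C)N[C@@H](C)C5)cc4)n[nH]c3c2)c1F` differs from compound 3 by 3,5-dimethylpiperazin-1-yl in place of 4-methyl-1,4-diazepan-1-yl on an aromatic carbon. The two have the same atoms, joined differently. For the measured compounds named here, no pair of measured compounds differing in one place is available, so no measured step sizes this change. The step of a 1.2-fold higher number from compound 3 to compound 4 (0.07 log units; within the scatter) is expected to stay within the usual scatter, with no clear direction. Compound 4 is estimated at 120 nM, within a range of 40 nM to 400 nM.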

Compound 4, half-maximal inhibitory concentration: 582 nM
Beside the measured number, compound 4's estimate is 4.9-fold (0.69 log units) below it; measured number above the stated range.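

In this assay, 3,5-dimethylpiperazin-1-yl in place of 4-methyl-1,4-diazepan-1-yl gives a 5.7-fold higher number from compound 3 to compound 4 (0.76 log units; beyond the scatter), so this position, para to a large group, responds to the choice of amine ring even though the two compounds have the same atoms. The entering group differs at once in ring size, hydrogen-bond donor count and defined stereocentres, and this single step cannot assign the change to any one of these. Compound 1 and compound 2 each give only a limit of the assay and not a number: the limit of > 1000 nM in this assay, at which 2 of the 4 values shown sit.

Open, going by these compounds, is how an unsubstituted piperazin-1-yl or a morpholin-4-yl would read at this position on the core of compound 3, a comparison that could separate ring size from the methyl groups. On these data alone, the contribution of the stereocentres also remains open.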